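Benzyloxy in place of mesyloxy on the benzamide ring

The source may report more compounds than this note shows. Statements on the series, on what has been measured and on what is new or still open speak of the compounds shown alone.

Compound 1 `Cc1cccc(NC(=O)c2ccccc2)n1`: 35000 nM
Compound 2 `Cc1cccc(C(=O)Nc2cccc(C)n2)c1`: 1840 nM
Compound 3 `Cc1cccc(NC(=O)c2cccc(OS(C)(=O)=O)c2)n1`: 83600 nM

In an assay on membranes from brain for binding affinity to metabotropic glutamate receptor 5 (Rattus norvegicus) (a lower number here means a stronger inhibitor, a higher number a weaker inhibitor), compound 3 gives the highest number of the three, and both gaps to it lie beyond the scatter: a 2.4-fold higher number from compound 1 to compound 3 (0.38 log units; beyond the scatter) and a 45-fold higher number from compound 2 to compound 3 (1.66 log units; beyond the scatter). Compound 4 `Cc1cccc(NC(=O)c2cccc(OCc3ccccc3)c2)n1` differs from compound 3 in one place: benzyl in place of methylsulfonyl on an oxygen on an aromatic ring. Both measured steps that bear on this show that the (methylsulfonyl)oxy group is the worst of the substituents tried at this position, against hydrogen and, more strongly, against methyl. Removing the methylsulfonyl in favour of benzyl is therefore expected to lower the number, though the new group is larger than either comparator. Compound 4 is estimated at 2500 nM, with a range of 400 nM to 15000 nM, a step of a 33-fold lower number from compound 3 to compound 4 (1.52 log units; beyond the scatter).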

Compound 4, half-maximal inhibitory concentration: 33000 nM
The estimate for compound 4 lay 13-fold (1.12 log units) below the measured number; measured number outside the range, above it.
By their numbers in this assay, from the lowest: compound 2; then compounds 4 and 1 (each within the scatter of the next); then compound 3.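

In this assay benzyloxy gives back only a modest part of what the (methylsulfonyl)oxy group costs (a 2.5-fold lower number from compound 3 to compound 4 (0.40 log units; beyond the scatter)). Set against hydrogen at this place, the larger group brings no change beyond the scatter (a 1.1-fold lower number from compound 1 to compound 4 (0.03 log units; within the scatter)). Methyl therefore stays well ahead of it (an 18-fold higher number from compound 2 to compound 4 (1.25 log units; beyond the scatter)), and no measurement at hand explains these differences.

From the compounds shown here alone, whether methoxy, a chlorine atom or an amine at this place would reach the number of compound 2 remains open. So does whether any group here could go lower than methyl.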